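The source may report more compounds than this note shows. Statements on the series, on what has been measured and on what is new or still open speak of the compounds shown alone.

Measured so far:
Compound 1, `N#CC1=C(NCC(=O)N2CCCC2)N(c2ccccc2)C(=O)N2CCCCC(N3CCCC3)C12`: 40.1%
Compound 2, `CCOC(=O)C(=O)NC1=C(C#N)C2C(N3CCCC3)CCCCN2C(=O)N1c1ccccc1`: 71.2%

Both compounds were tested in a functional assay on the whole organism (strain albino) for inhibition, with Rattus norvegicus as the target, read by paw edema, with a stated time of 1 h, at a dose of 20 mmol/kg by the intraperitoneal route; a higher number here means more inhibition at the dose given (going by the name of the read-out), a lower number less inhibition. Among the compounds with values here, compound 2 holds the higher of the two numbers, and the single measured step, a number 31.1 percentage points higher from compound 1 to compound 2 (beyond the scatter), is a large one that lies well beyond the scatter. Compound 3, `N#CC1=C(NCC(=O)N2CCCCC2)N(c2ccccc2)C(=O)N2CCCCC(N3CCCC3)C12`, has not yet been measured. It differs from compound 2 in one place: ((piperidin-1-yl)carbonyl)methyl in place of (ethoxycarbonyl)carbonyl on an amine nitrogen. In plain terms, the group that entered when compound 1 became compound 2 now leaves again, and a group of the same general kind as the one that left then comes back, only with a six-membered ring in place of a five-membered one. Within the data shown here, the one measured step therefore bears directly on this change, and it points downward when run in reverse. A drop of roughly that size is expected, with some allowance for the ring not being identical. Compound 3 is thus estimated at 45%, most likely between 25% and 65%, an expected step of a number 26.2 percentage points lower from compound 2 to compound 3 (beyond the scatter).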

Compound 3, a percentage reported as inhibition, in the whole organism at one dose (the size of the read-out at that dose, not a potency): 38%
Beside the measured number, compound 3's estimate is 7 percentage points above it; low and high end bracket the measured number.
By their numbers in this assay, from the lowest: compounds 3 and 1 (each within the scatter of the next); then compound 2.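

On the amine nitrogen, replacing (ethoxycarbonyl)carbonyl with ((piperidin-1-yl)carbonyl)methyl brings a number 33.2 percentage points lower from compound 2 to compound 3 (beyond the scatter) in this assay, so a second amide-bearing group now stands well apart from compound 2. Exchanging pyrrolidin-1-yl for piperidin-1-yl on the carbonyl carbon brings a number 2.1 percentage points lower from compound 1 to compound 3 (within the scatter), so at this single dose, the change of ring in this pair does not separate the two compounds. Nothing measured here bears on the cause of the gap between compound 2 and these two amides.

Compound 2 differs from compound 1 and compound 3 in more than one feature of this group, so these compounds do not show which part of (ethoxycarbonyl)carbonyl goes with its higher number. A simple acetyl group, the free carboxylic acid, or a piperidine amide joined directly to the carbonyl next to the amine nitrogen would help to separate those features, and a morpholine amide would test whether a further hetero atom in the ring matters.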